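The compounds below may be only part of what the source reports. "The series", "measured", "known", "first", "only" and "open" are said of these compounds alone.

Three compounds share one core and differ only in the group on the outer aromatic ring. Compound 1 `O=C(Nc1nn[nH]n1)c1cc(Cl)cc(-c2ccc(Cl)cc2)n1` carries chloro there, compound 2 `COc1ccc(-c2cc(Cl)cc(C(=O)Nc3nn[nH]n3)n2)cc1` methoxy, and compound 3 `CC(C)c1ccc(-c2cc(Cl)cc(C(=O)Nc3nn[nH]n3)n2)cc1` isopropyl. In a functional assay on the whole organism with Rattus norvegicus as the target, at a dose of 3 mg/kg by the oral route (a lower number here means a weaker effect, a higher number a stronger effect of the compound at the dose given), compound 1 gives 11%, compound 2 gives 100% and compound 3 gives 68%. Compound 3 thus stands second of the three: a number 32 percentage points lower from compound 2 to compound 3 (beyond the scatter) and a number 57 percentage points higher from compound 1 to compound 3 (beyond the scatter).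

Compound 4 `CCCCc1ccc(-c2cc(Cl)cc(C(=O)Nc3nn[nH]n3)n2)cc1` differs from compound 3 in one place: butyl in place of isopropyl on an aromatic carbon. Among the compounds with values here, no measured step swaps one alkyl group for another. The steps that touch this position, a number 89 percentage points higher from compound 1 to compound 2 (beyond the scatter) and a number 57 percentage points higher from compound 1 to compound 3 (beyond the scatter), both replace chloro and were large, and a number 32 percentage points lower from compound 2 to compound 3 (beyond the scatter) shows that a change at this position can move the read-out well beyond the scatter. Without a direct guide, compound 4 is expected to stay fairly close to the level of compound 3, with wide uncertainty. The expected step is a number 8 percentage points lower from compound 3 to compound 4 (within the scatter). Compound 4 is therefore estimated at 60%, between 25% and 95%.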

Compound 4, a percentage reported as inhibition, in the whole organism at one dose (the size of the read-out at that dose, not a potency): 83%
For compound 4 the middle estimate is 23 percentage points below the measured one; the measured number falls inside the stated range.
By their numbers in this assay, from the lowest: compound 1; then compound 3; then compound 4; then compound 2.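

Even a swap from one alkyl group to another at this position moves the read-out in this assay: butyl in place of isopropyl gives a modest rise (a number 15 percentage points higher from compound 3 to compound 4 (beyond the scatter)). Butyl does not fully match methoxy (a number 17 percentage points lower from compound 2 to compound 4 (beyond the scatter)), yet it stands far above chloro (a number 72 percentage points higher from compound 1 to compound 4 (beyond the scatter)), so both alkyl groups and methoxy give a stronger effect at the dose given than chloro does. No measured evidence bears on why these groups differ.

As far as these compounds go, whether the gain from isopropyl to butyl follows the carbon count or the change from a branched to a straight chain remains open. Also open, from the compounds shown here alone, is how a propyl or hexyl chain, an amine or a carboxylic acid would behave at this position.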